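A few compounds are considered here, and "the series" means these few. Any claim that something is new, unique, unknown or untested is made for them only; others in the source may bear on it.

Working notes on the aminothiophene series. In a functional assay on CHO cells with adenosine receptor A1 (Homo sapiens) as the target, read by cAMP accumulation and immunoassay, with a stated time of 6 min, tested at 1 uM (on this read-out lower numbers stand for a stronger effect and higher numbers for a weaker effect at the one concentration tested), compound 2 `Nc1scc(CN2CCN(c3c(F)cccc3F)CC2)c1C(=O)c1ccc(Cl)cc1` gives -65%; compound 1 `Nc1scc(CN2CCN(c3cccc(C(F)(F)F)c3)CC2)c1C(=O)c1ccc(Cl)cc1` gives -72% in the same assay, and the two values lie within the scatter of each other, so compound 2 cannot be set apart from compound 1 on these numbers. Compound 3 `Nc1scc(CN2CCN(c3c(F)cc(F)cc3F)CC2)c1C(=O)c1ccc(Cl)cc1` remains to be measured in this assay. The change from compound 2 to compound 3 is fluoro in place of hydrogen on an aromatic carbon. Among the compounds with values here, the only measured step that bears on this change is a number 7 percentage points higher from compound 1 to compound 2 (within the scatter), which swapped the whole aryl group on the piperazine nitrogen and still stayed within the scatter; a single added fluoro on the same ring is a smaller alteration than that. No step beyond the scatter is therefore expected for compound 3, estimated as a number 2 percentage points higher from compound 2 to compound 3 (within the scatter). Compound 3 is expected to give about -63%, with a range from -80% to -42%.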

Compound 3, a percentage reported as activity, at one concentration (the size of the read-out at that concentration, not a potency): -56%
The estimate for compound 3 lay 7 percentage points below the measured number; low and high end bracket the measured number.
By their numbers in this assay, from the lowest: compounds 1, 2 and 3 (each within the scatter of the next, the first and the last beyond it).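

In this assay, fluoro in place of hydrogen on the aromatic carbon para to a large group, meta to two fluoro groups, gives a number 9 percentage points higher from compound 2 to compound 3 (within the scatter), so this single change cannot be told apart from the scatter. The aryl exchange on the amine nitrogen in a ring now gives a separable result: 2,4,6-trifluorophenyl in place of 3-(trifluoromethyl)phenyl gives a number 16 percentage points higher from compound 1 to compound 3 (beyond the scatter), the only step shown beyond the scatter and a modest one, whereas 2,6-difluorophenyl in the same place gave a number 7 percentage points higher from compound 1 to compound 2 (within the scatter). No measurement at hand accounts for this difference between the aryl groups.

Open, from the compounds shown here alone, is whether chloro, methoxy or an amine on this same aromatic carbon would move the number beyond the scatter from compound 2. With a single concentration as the read-out, how the potencies of these compounds compare also remains open.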